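A few compounds are considered here, and "the series" means these few. Any claim that something is new, unique, unknown or untested is made for them only; others in the source may bear on it.

Three compounds have already been measured in a functional assay on A549 cells (Homo sapiens) for cytotoxicity, read by MTT assay, with a stated time of 72 h; a higher number here means a weaker inhibitor, a lower number a stronger inhibitor:
compound 1 `C#Cc1cccc(Nc2ncnc3oc(C)c(C(=O)OCC)c23)c1`: > 1000000 nM
compound 2 `Cc1oc2ncnc(Nc3cccc(Br)c3)c2c1CO`: 102000 nM
compound 3 `Cc1oc2ncnc(Nc3ccccc3)c2c1C(=O)O`: 191000 nM

Compound 1 gives a limit of this assay, not a number: the limit of > 1000000 nM in this assay, at which 1 of the 3 values shown sits. Compound 2 and compound 3, which carry other groups on the shared core, both give numbers. The step from compound 1 to compound 4 `CCOC(=O)c1c(C)oc2ncnc(Nc3cccc(C)c3)c12` alters a single group: methyl in place of ethynyl on an aromatic carbon. Among the measured compounds shown here, no measured pair here differs in only one place, so no measured step shows what this change does. The expectation for compound 4 is a step of about a number no higher from compound 1 to compound 4 (the limit leaves the size open), which is none beyond the scatter. Compound 4 is therefore expected to give around 1000000 nM, within 200000 nM to 5000000 nM, and may again return only a limit.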

Compound 4, half-maximal inhibitory concentration: > 1000000 nM
Compound 4: no number, only a limit (the forecaster's own chance of this, stated with the estimate: 60%); the middle value lies on the limit itself.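

Among the compounds shown here, compound 1 and compound 4 both give only a limit, so no step between them can be read: the limit of > 1000000 nM in this assay, at which 2 of the 4 values shown sit. The compounds shown leave open whether methyl in place of ethynyl changes cytotoxicity at all.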